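A Bromo Exchange on a Compound Reported Inactive

The source may report more compounds than this note shows. Statements on the series, on what has been measured and on what is new or still open speak of the compounds shown alone.

Three compounds built on the core of compound 1 `O=C(CCCCC1CCSS1)Nc1cccc(C(F)(F)F)c1` have so far been examined. In a functional assay on KB cells (Homo sapiens) for inhibition, read by MTT assay, with a stated time of 24 h, tested at 0.1 ug/mL (on this read-out lower numbers stand for less inhibition of growth and higher numbers for more inhibition of growth at the one concentration tested), compound 1 gives 0.33% as its result. Compound 2 `O=C(CCCCC1CCSS1)Nc1ccccn1` is recorded as "not active" (no number reported) without any number. Compound 3 `O=C(CCCCC1CCSS1)Nc1ccc(Cl)cn1` is likewise recorded as "not active" (no number reported) and so has no single number. It shares that entry with compound 2 and cannot be ranked against compound 1 on a number.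

Compound 4 `O=C(CCCCC1CCSS1)Nc1ccc(Br)cn1` remains unmeasured and carries one change from compound 3 (bromo in place of chloro on an aromatic carbon), with bromo in place of chloro on an aromatic carbon, two atoms from the ring nitrogen and para to a large group. Among the measured compounds shown here, no measured pair here shows what such an exchange does, so the expectation rests on the results alone. Compound 3 at "not active" (no number reported) and compound 1 at 0.33% offer no sign that a large move should be expected. In this assay no step beyond the usual scatter is expected from this exchange, in either direction. For compound 4 the estimated value is 1% with 0% to 8% as the expected range.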

Compound 4, percent growth inhibition at one concentration: "not active" (no number reported)
Compound 4: no number reported, and the estimate cannot be compared.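

In this assay, among the compounds shown here, compound 3 and compound 4 both stand without a number, so no step from chloro to bromo can be read between them. The compounds shown leave open whether this exchange changes growth inhibition at all. No measurement given here bears on why the two compounds are recorded this way.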